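The compounds below may be only part of what the source reports. "The series", "measured", "known", "first", "only" and "open" are said of these compounds alone.

Compound 1 `CCOC(=O)Cn1c(=O)c(-c2ccc(OC)cc2)cc2c(OC)cc(OC)cc21` is one of two measured members of this series. In a functional assay on A-427 cells (Homo sapiens) for cytotoxicity, read by colorimetric assay and MTT assay (on this read-out higher numbers stand for weaker inhibition and lower numbers for stronger inhibition), compound 1 gives 10000 nM, level with compound 2 `COc1ccc(-c2cc3c(OC)cc(OC)cc3n(CCCC#N)c2=O)cc1`, which in this assay gives 10000 nM. Among the measured compounds shown here, the one measured step, no change at the digits printed from compound 1 to compound 2 (within the scatter), exchanges a group on the chain carbon bound to the aromatic nitrogen and leaves the read-out unchanged. Compound 3 `CCN(CC)C(=O)CCn1c(=O)c(-c2ccc(OC)cc2)cc2c(OC)cc(OC)cc21` differs from compound 1 at the same place: (diethylcarbamoyl)methyl in place of ethoxycarbonyl on a saturated chain carbon bound to an aromatic nitrogen. For the measured compounds named here, since the only comparable step bore no change, no shift beyond the scatter is expected in this assay, and the step from compound 1 to compound 3 is estimated as no change at the digits printed from compound 1 to compound 3 (within the scatter). Compound 3 is therefore expected to give about 10000 nM in this assay, between 5000 nM and 20000 nM.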

Compound 3, half-maximal inhibitory concentration: 10000 nM
For compound 3 middle estimate and measured number coincide at the digits printed; low and high end bracket the measured number.
By their numbers in this assay, from the lowest: compounds 1, 2 and 3 (each within the scatter of the next).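

In this assay, a tertiary amide end group on the chain reads level with both the ester and the nitrile (no change at the digits printed from compound 1 to compound 3 (within the scatter); no change at the digits printed from compound 2 to compound 3 (within the scatter)). The series at this place on the chain now spans three different end groups, with no step beyond the scatter. Nothing available explains this flat read-out.

From the compounds shown here alone, whether a carboxylic acid or a basic amine at the end of the chain would separate from compound 1, compound 2 and compound 3 stays open. So does the effect of replacing a methoxy group on the shared core with hydroxy.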